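Moving the pyridine nitrogen: compound 3 to compound 4

The source may report more compounds than this note shows. Statements on the series, on what has been measured and on what is new or still open speak of the compounds shown alone.

compound 1 `Cn1nc(C(=O)Nc2ccc(-c3ccccc3)c(C(F)(F)F)c2)c(=O)c2ccccc21` gives 2.3 10^-6 cm/s
compound 2 `Cn1cc(C(=O)Nc2ccc(-c3ccccc3)c(C(F)(F)F)c2)c(=O)c2ccccc21` gives 1.2 10^-6 cm/s
compound 3 `Cn1cc(C(=O)Nc2ccc(-c3cccnc3)c(C(F)(F)F)c2)c(=O)c2ccccc21` gives 18 10^-6 cm/s

In an ADME assay on LLC-PK1 cells (Sus scrofa) for permeability (a higher number here means that the compound crosses the layer faster, a lower number that the compound crosses the layer more slowly), compound 3 gives 18 10^-6 cm/s and stands highest of the three, with both other values beyond the usual scatter below it. Next comes compound 4 `Cn1cc(C(=O)Nc2ccc(-c3ccncc3)c(C(F)(F)F)c2)c(=O)c2ccccc21` which differs from compound 3 in one group: pyridin-4-yl in place of pyridin-3-yl on an aromatic carbon. The two hold the same atoms, joined differently.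

Among the measured compounds shown here, one measured step bears on this: a 15-fold higher number from compound 2 to compound 3 (1.18 log units; beyond the scatter) when pyridin-3-yl replaced phenyl. For the measured compounds named here, that large step involved phenyl, and no measured compound carries pyridin-4-yl, so it gives no direction for the new change. The expectation therefore stays anchored on compound 3 at 18 10^-6 cm/s and no step beyond the scatter is expected in this assay although a larger one cannot be excluded. The estimated change is small (a 1.3-fold lower number from compound 3 to compound 4 (0.11 log units; within the scatter)). Compound 4 is estimated at 14 10^-6 cm/s (expected range 6 10^-6 cm/s to 30 10^-6 cm/s).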

Compound 4, apparent permeability in the LLC-PK1 assay: 15 10^-6 cm/s
The estimate for compound 4 lay 1.1-fold (0.03 log units) below the measured number; measured number inside the range.
By their numbers in the LLC-PK1 assay, from the lowest: compounds 2 and 1 (each within the scatter of the next); then compounds 4 and 3 (each within the scatter of the next).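

In the LLC-PK1 assay, moving the ring nitrogen from pyridin-3-yl to pyridin-4-yl on this aromatic carbon, ortho to a trifluoromethyl group, leaves compound 3 and compound 4 within the scatter of each other (a 1.2-fold lower number from compound 3 to compound 4 (0.08 log units; within the scatter)). The large step away from phenyl is therefore seen with both pyridines, not just with pyridin-3-yl (a 13-fold higher number from compound 2 to compound 4 (1.10 log units; beyond the scatter)). The same swap does separate the two compounds in a physicochemical assay for solubility, at pH 7.4 (a higher number here means a more soluble compound, a lower number a less soluble compound), where compound 3 gives 23 ug/mL and compound 4, the less soluble, gives 6.4 ug/mL, so two isomers that look alike in one assay can differ in another: the measured solubility of compound 3, 23 ug/mL, and of compound 4, 6.4 ug/mL, a 3.6-fold lower number (0.56 log units; beyond the scatter).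

The compounds shown leave open how a pyridin-2-yl or a pyrimidin-5-yl group on this carbon would compare in both assays. They also leave open whether either pyridine would give a similar step on the core of compound 1.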